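Extending the side chain of compound 3 with a protected amine

The compounds below may be only part of what the source reports. "The series", "measured", "known", "first", "only" and "open" are said of these compounds alone.

Measured so far:
- compound 1, `O=C(CN(c1ncnc2c1ncn2C1CCCCO1)C1CC1)NCC(=O)OCc1ccccc1`: 17.2%
- compound 2, `NC(=O)C[C@H](NC(=O)CN(c1ncnc2c1ncn2C1CCCCO1)C1CC1)C(=O)OCc1ccccc1`: 29.2%
- compound 3, `C[C@H](NC(=O)CN(c1ncnc2c1ncn2C1CCCCO1)C1CC1)C(=O)OCc1ccccc1`: 25.3%

In a functional assay on the whole organism (Tail, strain ICR) with Mus musculus as the target, in the tail flick test, with a stated time of 120 min, at a dose of 25 umol/kg by the oral route (on this read-out higher numbers stand for a stronger effect at the one dose given and lower numbers for a weaker effect), compound 3 stands second highest of the three, with its distance to compound 2 and to compound 1 both within the scatter. Compound 4 is `CC(C)(C)OC(=O)NCCCC[C@H](NC(=O)CN(c1ncnc2c1ncn2C1CCCCO1)C1CC1)C(=O)OCc1ccccc1`; it differs from compound 3 by 3-((tert-butoxycarbonyl)amino)propyl in place of hydrogen on a saturated chain carbon, two bonds along the chain from an amide-type nitrogen and a carbonyl carbon. Among the compounds with values here, two measured steps bear on this: a number 12 percentage points higher from compound 1 to compound 2 (beyond the scatter) and a number 3.9 percentage points lower from compound 2 to compound 3 (within the scatter). Adding a side chain at this place gave at most a modest rise, and a larger chain is not clearly better than a small one. For compound 4 the expected step is therefore a number 1.7 percentage points higher from compound 3 to compound 4 (within the scatter), not beyond the scatter. Compound 4 is estimated at 27%, within 12% to 42%.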

Compound 4, a percentage reported as activity, at one dose (the size of the read-out at that dose, not a potency): 28.4%
Beside the measured number, compound 4's estimate is 1.4 percentage points below it, and the stated range covers the measured number.
By their numbers in this assay, from the lowest: compounds 1, 3, 4 and 2 (each within the scatter of the next, the first and the last beyond it).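

In this assay, the much larger 3-((tert-butoxycarbonyl)amino)propyl group is tolerated at this place: there is a number 3.1 percentage points higher from compound 3 to compound 4 (within the scatter), and a number 0.8 percentage points lower from compound 2 to compound 4 (within the scatter). Measured against the hydrogen-bearing chain carbon, there is a number 11.2 percentage points higher from compound 1 to compound 4 (beyond the scatter), so a substituent that clears the scatter here need not be the small carbamoylmethyl, although methyl goes against this pattern, as the step to compound 3 stays within the scatter. No measurement shown gives a reason for these numbers.

Going by these compounds, whether a free amine at the end of this chain, or a carboxylic acid there, would give a different reading stays open.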